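Chloro in Place of Nitro on a Fused Bicyclic Amine

A few compounds are considered here, and "the series" means these few. Any claim that something is new, unique, unknown or untested is made for them only; others in the source may bear on it.

The three measured compounds and their readings:

Compound 1, `Nc1ccccc1NC(=O)c1ccc(CSC(=S)N2CCN(C3CCCCC3)CC2)cc1`: 76.1%
Compound 2, `Nc1ccccc1NC(=O)c1ccc(CSC(=S)N2CCc3cc([N+](=O)[O-])ccc32)cc1`: 43.6%
Compound 3, `Nc1ccccc1NC(=O)c1ccc(CSC(=S)N2CCN(C(c3ccccc3)c3ccccc3)CC2)cc1`: 13.8%

All three share the same core and were tested in a functional assay on HeLa cells (Homo sapiens) for antiproliferative activity, read by CCK-8 assay, with a stated time of 72 h, tested at 8 uM; on this read-out higher numbers stand for a stronger effect at the one concentration tested and lower numbers for a weaker effect. They differ only in the amine attached to the thiocarbonyl group. Compound 2 stands second of the three on these numbers: compound 1 lies above it by a margin beyond the usual scatter, and compound 3 lies below it, also beyond the scatter. None of the three pairs differs in just one place, so no single change can be read off from the measured set.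

Compound 4, `Nc1ccccc1NC(=O)c1ccc(CSC(=S)N2CCc3cc(Cl)ccc32)cc1`, keeps the fused bicyclic amine of compound 2 and differs from it only by chloro in place of nitro on an aromatic carbon. For the measured compounds named here, no measured pair shows this kind of exchange, so the data give no direct guide to its size. The expectation is that in this assay the change produces no step beyond the scatter in either direction. Compound 4 is therefore expected to give about 45%, with a range from 22% to 68%. The step this estimate implies, a number 1.4 percentage points higher from compound 2 to compound 4 (within the scatter), is expected to be small.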

Compound 4, a percentage reported as inhibition, at one concentration (the size of the read-out at that concentration, not a potency): 65.1%
Compound 4: the middle estimate sits 20.1 percentage points below what was measured; measured number inside the range.
By their numbers in this assay, from the lowest: compound 3; then compound 2; then compound 4; then compound 1.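

For the compounds shown here, until this result, the fused bicyclic amine had been seen with only one group on its aromatic ring, so nothing showed whether that group mattered for the reading. In this assay, the exchange of nitro for chloro on this aromatic carbon gives a number 21.5 percentage points higher from compound 2 to compound 4 (beyond the scatter), which shows that the group at this one position can alter the effect on the cells even when the amine framework and the rest of the molecule stay the same. The change takes away three heavy atoms and two hydrogen-bond acceptors and puts a single chlorine in their place, but no measurement here explains why the reading rises with this exchange.

With only nitro and chloro shown at this position, it remains open how a methoxy group, an amine, a fluoro group or plain hydrogen would compare there. From the compounds shown here alone, it also remains open whether the same exchange would give a step of similar size on a different amine, and a reading at a single concentration says nothing about potency.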